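This account rests on a few compounds, and the source may have more. Where it says the series, first, only, none or still open, it means among the compounds named here.

Measured so far in an ADME assay on Vero cells (Chlorocebus sabaeus) for cytotoxicity, read by neutral red uptake, tested at 49 ug/mL; a higher number here means a weaker effect of the compound at the concentration tested, a lower number a stronger effect:

Compound 1 `O=C1CSC(c2c(Cl)cccc2Cl)N1CCN1CCCCC1`; compound 1 gives 100%.
Compound 2 `O=C1CSC(c2cccc(Cl)c2)N1CCN1CCCCC1`; compound 2 gives 100%.
Compound 3 `COc1ccccc1C1SCC(=O)N1CCN1CCCCC1`; compound 3 gives 100%.

Compound 2 stands level with compound 1 and with compound 3 at the digits shown; the values of all three fall within the scatter of one another, so nothing separates them in this assay. Going by the values given here, no step between measured compounds is set out here, and the three values give no sign of the aromatic substituent on the saturated ring carbon mattering for the read-out at the concentration tested.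

Compound 4 `O=C1CSC(c2ccc(F)cc2)N1CCN1CCCCC1` is the next compound for this assay. It differs from compound 2 by 4-fluorophenyl in place of 3-chlorophenyl on a saturated ring carbon. With compounds 1, 2 and 3 all at the same reading, no step beyond the scatter is expected from compound 2 to compound 4; a step of no change at the digits printed from compound 2 to compound 4 (within the scatter) is the estimate. Compound 4 is thus expected to give 100%, with a range from 88% to 100%.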

Compound 4, a percentage reported as activity, at one concentration (the size of the read-out at that concentration, not a potency): 100%
Compound 4: the middle estimate sits on the measured number at the digits printed; low and high end bracket the measured number.
By their numbers in this assay, from the lowest: compounds 1, 2, 3 and 4 (each within the scatter of the next).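

In this assay, going by these compounds alone, 4-fluorophenyl in place of 3-chlorophenyl on the saturated ring carbon gives the first direct step at this position: no change at the digits printed from compound 2 to compound 4 (within the scatter). This step changes both the halogen and its place on the phenyl ring, so the two changes cannot be read apart, but together they leave the reading within the scatter. No measurement bearing on the reason for this result is available.

All groups shown at this position are substituted phenyl rings, so it stays open whether an amine or a carboxylic acid on the phenyl ring, or a cyclohexyl group in place of it, would move the reading. The compounds shown vary only at this position, so changes elsewhere on the shared core also remain open.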